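Hydroxy for hydrogen on the hydroxylated ring of compound 2

This account rests on a few compounds, and the source may have more. Where it says the series, first, only, none or still open, it means among the compounds named here.

Going by the values given here, compound 2 `O=C(/C=C/c1ccc(O)cc1)NNC(=O)c1ccc(O)cc1` sits in the middle of the three numbers measured so far; in a functional assay on NCI-H1299 cells (Homo sapiens) for antiproliferative activity, read by MTT assay, with a stated time of 24 h (on this read-out lower numbers stand for stronger inhibition and higher numbers for weaker inhibition), compound 2 gives 5470 nM. Its nearest neighbour is compound 3 `COc1ccc(C(=O)NNC(=O)/C=C/c2ccc(O)c(OC)c2)cc1`, which gives 5420 nM, and the furthest is compound 1 `COc1ccc(C(=O)NNC(=O)/C=C/c2ccc(O)cc2)cc1`, with 6640 nM; the gap to either lies within the scatter, so the three cannot be ordered.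

Compound 4 `O=C(/C=C/c1ccc(O)c(O)c1)NNC(=O)c1ccc(O)cc1` is the next member: hydroxy in place of hydrogen on an aromatic carbon.

Among the compounds with values here, two measured steps bear on it. The step of a 1.2-fold lower number from compound 1 to compound 3 (0.09 log units; within the scatter) introduces a methoxy into the same place that the hydroxy takes in compound 4, and it did not move the number beyond the scatter. The step of a 1.2-fold lower number from compound 1 to compound 2 (0.08 log units; within the scatter), which exchanges methyl for hydrogen on an oxygen and so turns a methoxy into a hydroxy elsewhere on the shared core, was likewise within the scatter. Neither change so far has shifted this read-out beyond noise, so no step beyond the scatter is expected from compound 2 to compound 4 in this assay .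

Compound 4 is therefore expected at about 5000 nM, between 2500 nM and 10000 nM, the expected step being a 1.1-fold lower number from compound 2 to compound 4 (0.04 log units; within the scatter).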

Compound 4, half-maximal inhibitory concentration: 4480 nM
Compound 4: the middle estimate sits 1.1-fold (0.05 log units) above what was measured; measured number inside the range.
By their numbers in this assay, from the lowest: compounds 4, 3, 2 and 1 (each within the scatter of the next).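

In this assay, a 1.2-fold lower number from compound 2 to compound 4 (0.09 log units; within the scatter) extends the picture at this aromatic carbon, ortho to a hydroxy group and meta to a large group: a hydroxy can now be read there as well as a methoxy. Set beside a 1.2-fold lower number from compound 1 to compound 3 (0.09 log units; within the scatter), it gives two oxygen-linked groups at this carbon, each read on a different partner, and both steps stay within the scatter, so neither group can be ranked against hydrogen at this position. Nothing available accounts for this flat result or ties it to any property of the hydroxy.

From the compounds shown here alone, all four compounds remain within the scatter of one another, so it remains open whether any change at this carbon can produce a step beyond the scatter in this read-out. An amine or a carboxylic acid in place of the hydroxy, or a longer chain such as ethoxy or propoxy in place of the methoxy, would test whether this position is as unresponsive to groups other than hydroxy and methoxy as these compounds suggest.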